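Weak Series, a Dinitrophenyl Variant Awaits Its Number

This account rests on a few compounds, and the source may have more. Where it says the series, first, only, none or still open, it means among the compounds named here.

Compound 3 `Cc1ccc(-n2nncc2CN2C(=O)C3(C(C#N)=C(N)Oc4c(N)cc5nc6ccccc6nc5c43)c3ccccc32)cc1C` bears a 3,4-dimethylphenyl group on an aromatic nitrogen of the shared core. In a functional assay on HepG2 cells (Homo sapiens) for antiproliferative activity, read by MTT assay, with a stated time of 48 h (a higher number here means a weaker inhibitor, a lower number a stronger inhibitor), compound 3 reaches only the limit of the assay, > 50000 nM, and no number. The same holds for compound 2 `CCOc1ccc(-n2nncc2CN2C(=O)C3(C(C#N)=C(N)Oc4c(N)cc5nc6ccccc6nc5c43)c3ccccc32)cc1`, whose value in this assay is also a limit, > 50000 nM. Within the data shown here, compound 1 `N#CC1=C(N)Oc2c(N)cc3nc4ccccc4nc3c2C12C(=O)N(Cc1cnnn1-c1ccccc1Br)c1ccccc12`, with a 2-bromophenyl group at that position, is the only member with a number: in this assay compound 1 gives 38000 nM. The step of an at least 1.3-fold higher number from compound 1 to compound 2 (0.11 log units; that floor lies within the scatter) and the step of an at least 1.3-fold higher number from compound 1 to compound 3 (0.11 log units; that floor lies within the scatter) both begin from a number and end at a limit, while the step that the two limits leave unreadable from compound 2 to compound 3 cannot be read at all. Compound 3 thus stands among the values that are limits, and the limit of > 50000 nM in this assay, at which 2 of the 3 values shown sit, is where it sits together with compound 2.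

Compound 4 `N#CC1=C(N)Oc2c(N)cc3nc4ccccc4nc3c2C12C(=O)N(Cc1cnnn1-c1ccc([N+](=O)[O-])cc1[N+](=O)[O-])c1ccccc12` differs from compound 3 in one place: 2,4-dinitrophenyl in place of 3,4-dimethylphenyl on an aromatic nitrogen. Among the measured compounds shown here, no measured step exchanges one aryl group for a 2,4-dinitrophenyl group, so the only steps that bear on it are the two leaving compound 1, both of which sit at a floor within the scatter. One therefore expects no step beyond the scatter, with an at least 1.1-fold lower number from compound 3 to compound 4 (0.04 log units; that floor lies within the scatter) as the estimated change. Compound 4 is expected to give 45000 nM in this assay, within a range from 20000 nM to 100000 nM, and it may again end at a limit.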

Compound 4, half-maximal inhibitory concentration: 18400 nM
Compound 4: the middle estimate sits 2.4-fold (0.39 log units) above what was measured; measured number outside the range, below it.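

Among these compounds, until now, no step at this aromatic nitrogen could be read as lying beyond the scatter, so the earlier compounds did not show that changing the aryl group here moves the read-out at all. In this assay, the change to 2,4-dinitrophenyl gives an at least 2.7-fold lower number from compound 3 to compound 4 (0.43 log units; beyond the scatter) and an at least 2.7-fold lower number from compound 2 to compound 4 (0.43 log units; beyond the scatter), and also a 2.1-fold lower number from compound 1 to compound 4 (0.31 log units; beyond the scatter), the only one of these steps that joins two numbers, so compound 4 is the strongest of the four shown, though all the steps are modest or rest on a floor. Compound 2 and compound 3 remain at a limit and not at a number, so the first two of these steps give only a floor and the step between those two compounds cannot be read: the limit of > 50000 nM in this assay, at which 2 of the 4 values shown sit.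

The compounds shown leave open whether both nitro groups are needed, as no phenyl group carrying a single nitro group appears among them. They also leave open how an amine or a carboxylic acid on that phenyl ring would compare with 2,4-dinitrophenyl at this position.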